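The source may report more compounds than this note shows. Statements on the series, on what has been measured and on what is new or still open speak of the compounds shown alone.

Compound 1 `COc1cccc(/C=C/C(=O)c2sc(Nc3ccccc3)nc2C)c1`, compound 2 `Cc1nc(Nc2cccc(Cl)c2)sc1C(=O)/C=C/c1ccccc1` and compound 3 `Cc1nc(Nc2ccccc2)sc1C(=O)/C=C/c1ccc(Cl)cc1` share one core and were all tested in a functional assay on PC-3 cells (Homo sapiens) for cytotoxicity, read by MTT assay; a lower number here means a stronger inhibitor, a higher number a weaker inhibitor. In this assay compound 1 gives > 25000 nM, which is a limit of the assay and not a number. In this assay compound 2 gives > 25000 nM, also a limit. In this assay compound 3 gives > 25000 nM, again a limit. For the measured compounds named here, because of the limit of > 25000 nM in this assay, at which 3 of the 3 values shown sit, the only step between two measured compounds, a step that the two limits leave unreadable from compound 1 to compound 3, cannot be read in size or direction. Compound 3 therefore stands at the limit with nothing to place it higher or lower.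

Compound 4 `Cc1nc(Nc2ccc(Cl)cc2)sc1C(=O)/C=C/c1ccc(Cl)cc1` differs from compound 3 by chloro in place of hydrogen on an aromatic carbon. Going by the values given here, no measured step follows this change, and the one step that exists is unreadable, so nothing points to a number for the new compound. Compound 4 is therefore expected to sit at about 30000 nM, within a range from 10000 nM to 100000 nM. The step expected from compound 3 to compound 4 is a step that the limit leaves unreadable from compound 3 to compound 4, which most likely means another limit rather than a measured number.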

Compound 4, half-maximal inhibitory concentration: > 25000 nM
Compound 4: only a limit was reported; the forecaster's own chance of this, stated with the estimate: 85%; the middle value is on the limit's open side.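

Compound 3 and compound 4 both stand at a limit of the assay, not at a number, so the step between them cannot be read: the limit of > 25000 nM in this assay, at which 4 of the 4 values shown sit.

The compounds shown leave open which change to the shared core, if any, would give a readable number in this assay.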